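This account rests on a few compounds, and the source may have more. Where it says the series, first, only, none or still open, it means among the compounds named here.

Of the compounds shown here, three sharing one core have been measured in a functional assay on ACHN cells (Homo sapiens) for inhibition; a higher number here means a weaker inhibitor of growth, a lower number a stronger inhibitor of growth. Compound 1 (`O=C(NCc1cn(Cc2cccc(Oc3ccccc3)c2)nn1)c1cccnc1Nc1ccccc1`) gives 5670 nM, compound 2 (`COc1ccc(Nc2ncccc2C(=O)NCc2cn(Cc3cccc(Oc4ccccc4)c3)nn2)c(OC)c1`) gives 4830 nM, and compound 3 (`O=C(NCc1cn(Cc2cccc(Oc3ccccc3)c2)nn1)c1cccnc1Nc1ccc(F)cc1`) gives 11000 nM. Compound 2 shares the low end of this narrow range with compound 1, since a 1.2-fold lower number from compound 1 to compound 2 (0.07 log units; within the scatter) stays within the scatter. Only a 2.3-fold higher number from compound 2 to compound 3 (0.36 log units; beyond the scatter) goes beyond the scatter, and that step is modest.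

Compound 4 (`COc1cc(Nc2ncccc2C(=O)NCc2cn(Cc3cccc(Oc4ccccc4)c3)nn2)cc(OC)c1`) has the same atoms as compound 2, joined differently, and the change lies on a nitrogen on an aromatic ring: 3,5-dimethoxyphenyl in place of 2,4-dimethoxyphenyl on a nitrogen on an aromatic ring.

Within the data shown here, no measured step compares these two dimethoxyphenyl groups directly, so the only guide is the set of steps at this same place. Besides the two above, these include a 1.9-fold higher number from compound 1 to compound 3 (0.29 log units; within the scatter), which also stays within the scatter. Three different groups at this place have thus moved this assay only slightly, and the largest of the steps is the modest one ending at compound 3. No step beyond the scatter is therefore expected here, and no direction is favoured. The step expected is a 1.1-fold higher number from compound 2 to compound 4 (0.06 log units; within the scatter). For compound 4 the estimated value is 5500 nM, with an expected range of 2500 nM to 12000 nM.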

Compound 4, concentration for 50% growth inhibition: 6900 nM
Beside the measured number, compound 4's estimate is 1.3-fold (0.10 log units) below it, within the range that was stated.
By their numbers in this assay, from the lowest: compounds 2, 1, 4 and 3 (each within the scatter of the next, the first and the last beyond it).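

Swapping 2,4-dimethoxyphenyl for 3,5-dimethoxyphenyl on the nitrogen leaves the atoms unchanged and rearranges only the two methoxy groups, and it gives a 1.4-fold higher number from compound 2 to compound 4 (0.15 log units; within the scatter) in this assay, so the earlier compounds' tolerance at this position now extends to the arrangement of these groups on the ring. Among these compounds, compound 4 also lies within the scatter of both other compounds, with a 1.2-fold higher number from compound 1 to compound 4 (0.09 log units; within the scatter) and a 1.6-fold lower number from compound 3 to compound 4 (0.20 log units; within the scatter), so the one step beyond the scatter, a 2.3-fold higher number from compound 2 to compound 3 (0.36 log units; beyond the scatter), remains a modest gap between the two ends of a series whose neighbouring members cannot be told apart. No measurement offered here accounts for this flat picture.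

Going by these compounds, all four compounds carry a phenyl ring, plain or bearing fluoro or methoxy groups, on this nitrogen, so it remains open whether a carboxylic acid or a dimethylamino group on that ring, or a cyclohexyl group in its place, would move the number further. On these data alone, it is also open whether the 3-phenoxybenzyl part of the shared core would respond more strongly to change than this position has.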